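The source may hold more compounds than are shown below. What is called first, only, known or untested is meant among the compounds shown, and "the series" means these compounds.

Measured so far in a physicochemical assay for solubility, read by nephelometry; a higher number here means a more soluble compound, a lower number a less soluble compound:
- Compound 1 `CN1CCN(CCCC(=O)c2ccc(-c3ccc(N4C[C@H](Cn5ccnn5)OC4=O)cc3F)cn2)CC1` gives > 400000 nM, which is a limit.
- Compound 2 `COCc1ccc(-c2ccc(N3C[C@H](Cn4ccnn4)OC3=O)cc2F)cn1` gives 100000 nM.

Among the compounds with values here, compound 2 stands at 100000 nM, the only actual number in this assay so far. Compound 3 `O=C(c1ccc(-c2ccc(N3C[C@H](Cn4ccnn4)OC3=O)cc2F)cn1)C1CNC1` carries (azetidin-3-yl)carbonyl in place of methoxymethyl on an aromatic carbon. Within the data shown here, one measured step bears on this change, an at least 4.0-fold lower number from compound 1 to compound 2 (0.60 log units; beyond the scatter), where methoxymethyl replaced (3-(4-methylpiperazin-1-yl)propyl)carbonyl. The new change runs the opposite way, from methoxymethyl to a carbonyl group, so a higher number is expected. The expected size is a 2.5-fold higher number from compound 2 to compound 3 (0.40 log units; beyond the scatter). The estimate for compound 3 is 250000 nM, with a range of 120000 nM to 400000 nM.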

Compound 3, solubility: 200000 nM
The estimate for compound 3 lay 1.3-fold (0.10 log units) above the measured number; low and high end bracket the measured number.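

Within the data shown here, replacing methoxymethyl with (azetidin-3-yl)carbonyl on this aromatic carbon gives the first step at this position with real numbers at both ends in this assay: a 2.0-fold higher number from compound 2 to compound 3 (0.30 log units; within the scatter). With the carbonyl kept, azetidin-3-yl in place of 3-(4-methylpiperazin-1-yl)propyl gives an at least 2.0-fold lower number from compound 1 to compound 3 (0.30 log units; that floor lies within the scatter). That step has only a floor, since compound 1 gives a limit: the limit of > 400000 nM in this assay, at which 1 of the 3 values shown sits.

Going by these compounds, the true size of the step from compound 1 stays open. Also open, on these data alone, is how a carboxylic acid or an open-chain dimethylaminomethyl group on this aromatic carbon would read in this assay.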